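The source may report more compounds than this note shows. Statements on the series, on what has been measured and on what is new or still open speak of the compounds shown alone.

In a functional assay on SK-MEL-2 cells (Homo sapiens) for cytotoxicity (on this read-out higher numbers stand for weaker inhibition and lower numbers for stronger inhibition), compound 1 `Cc1ccc2c(S)nc(-c3ccccc3)cc2c1` gives 19500 nM; 25100 nM (2 entries) and compound 2 `COc1ccc(-c2cc3cc(C)ccc3c(N3CCN(C)CC3)n2)cc1` gives 3710 nM, the lower of the numbers shown. One further entry for compound 2 carries no single number. Compound 3 `Cc1ccc2c(N3CCN(C)CC3)nc(-c3ccc(Cl)cc3)cc2c1` has not yet been measured. It differs from compound 2 in one place: chloro in place of methoxy on an aromatic carbon. This puts chloro in place of methoxy on an aromatic carbon, para to a large group, so that 4-methoxyphenyl becomes 4-chlorophenyl. Going by the values given here, no measured pair shows what such a change does in this assay, so the data give no size for it. The expected step, a 1.1-fold lower number from compound 2 to compound 3 (0.03 log units; within the scatter), stays within the usual scatter, with neither direction favoured. The expectation therefore rests on compound 2 at 3710 nM. For compound 3, the estimated value is 3500 nM, with an expected range of 1500 nM to 9000 nM.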

Compound 3, half-maximal inhibitory concentration: 2400 nM
Estimate against measurement, compound 3: 1.5-fold (0.16 log units) above, and the stated range covers the measured number.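

Going by these compounds alone, compound 2 and compound 3 form the first measured pair that puts a size on a change at this position: in this assay, chloro in place of methoxy on an aromatic carbon, para to a large group, gives a 1.5-fold lower number from compound 2 to compound 3 (0.19 log units; within the scatter). The two compounds therefore cannot be told apart on this read-out, even though the exchange removes the hydrogen-bond acceptor counted for methoxy. The repeated entries of compound 1 show how far two readings of one compound can lie from each other: the several entries of compound 1 in this assay, 19500 nM; 25100 nM (2 entries)

The compounds shown leave open whether an amine, a carboxylic acid or a longer alkoxy chain at this position would move the number beyond the scatter. Within the data shown here, compound 1 differs from compound 2 and compound 3 in more than one place, so it gives no step for either of them.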